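This account rests on a few compounds, and the source may have more. Where it says the series, first, only, none or still open, it means among the compounds named here.

Measured in a functional assay on PC-3 cells (Homo sapiens) for antiproliferative activity, read by MTT assay, with a stated time of 72 h; a lower number here means a stronger inhibitor, a higher number a weaker inhibitor:
compound 1, `CC(C)c1ccc(/C=C/C(=O)c2ccc(OCC(=O)N[C@H]3CCOC3=O)cc2)cc1`: 4660 nM
compound 2, `O=C(COc1ccc(C(=O)/C=C/c2cccc(Cl)c2)cc1)N[C@H]1CCOC1=O`: 4990 nM
compound 3, `O=C(COc1ccc(C(=O)/C=C/c2ccc(F)cc2)cc1)N[C@H]1CCOC1=O`: 15600 nM

Compound 3 gives the highest number of the three: the steps of a 3.3-fold higher number from compound 1 to compound 3 (0.52 log units; beyond the scatter) and a 3.1-fold higher number from compound 2 to compound 3 (0.50 log units; beyond the scatter) are both beyond the scatter, whereas a 1.1-fold higher number from compound 1 to compound 2 (0.03 log units; within the scatter) lies within it.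

Compound 4, `O=C(COc1ccc(C(=O)/C=C/c2ccc(Cl)cc2Cl)cc1)N[C@H]1CCOC1=O`, is not yet measured. Its change from compound 3: 2,4-dichlorophenyl in place of 4-fluorophenyl on a double-bonded chain carbon bound to a double-bonded chain carbon. Among the measured compounds shown here, the closest precedent is the ring swap a 3.1-fold higher number from compound 2 to compound 3 (0.50 log units; beyond the scatter), which read in the reverse direction, toward a chlorine-bearing ring, lowers the number; a 3.3-fold higher number from compound 1 to compound 3 (0.52 log units; beyond the scatter) points the same way. For the measured compounds named here, a second chlorine on that ring has no precedent in this set. For compound 4 in this assay a modest fall is therefore expected, of about the size of those steps, namely a 3.1-fold lower number from compound 3 to compound 4 (0.49 log units; beyond the scatter). Compound 4 is estimated at 5000 nM, with a range of 2000 nM to 13000 nM.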

Compound 4, half-maximal inhibitory concentration: 8040 nM
Compound 4: the middle estimate sits 1.6-fold (0.21 log units) below what was measured, and the stated range covers the measured number.
By their numbers in this assay, from the lowest: compounds 1, 2, 4 and 3 (each within the scatter of the next, the first and the last beyond it).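

In this assay, the 2,4-dichlorophenyl group at this position cannot be separated from any of the three earlier rings: a 1.9-fold lower number from compound 3 to compound 4 (0.29 log units; within the scatter) and a 1.6-fold higher number from compound 2 to compound 4 (0.21 log units; within the scatter) and also a 1.7-fold higher number from compound 1 to compound 4 (0.24 log units; within the scatter) each lie within the scatter. The 4-fluorophenyl and 4-isopropylphenyl rings stay apart beyond the scatter, so compound 4 does not join either one alone. Nothing measured here gives a reason for these readings.

Open, on these data alone, is how this position would respond to a ring carrying an amine or a carboxylic acid. As far as these compounds go, a longer chain in place of the ring also remains untested by these compounds.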